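Lengthening the Ester Chain: From Compound 3 to Compound 4

A few compounds are considered here, and "the series" means these few. Any claim that something is new, unique, unknown or untested is made for them only; others in the source may bear on it.

The measured compounds in a functional assay on SK-BR-3 cells (Homo sapiens) for antiproliferative activity, read by MTT assay, with a stated time of 72 h; a higher number here means a weaker inhibitor, a lower number a stronger inhibitor:
compound 1 `C/C=C1/[C@H](O[C@@H]2O[C@H](COC(C)=O)[C@@H](OC(C)=O)[C@H](OC(C)=O)[C@H]2OC(C)=O)OC=C(C(=O)OC)[C@H]1CC(=O)OCCC` gives 6600 nM;
compound 2 `C/C=C1/[C@H](O[C@@H]2O[C@H](COC(C)=O)[C@@H](OC(C)=O)[C@H](OC(C)=O)[C@H]2OC(C)=O)OC=C(C(=O)OC)[C@H]1CC(=O)OCCC1CCCCC1` is reported only as the limit > 15000 nM;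
compound 3 `C/C=C1/[C@H](O[C@@H]2O[C@H](COC(C)=O)[C@@H](OC(C)=O)[C@H](OC(C)=O)[C@H]2OC(C)=O)OC=C(C(=O)OC)[C@H]1CC(=O)OC` is reported only as the limit > 15000 nM.

Compound 3 thus stands at the top of the numbers shown, with no actual value, only a limit, and one further value shown in this assay sits at that same limit. Compound 4 `C/C=C1/[C@H](O[C@@H]2O[C@H](COC(C)=O)[C@@H](OC(C)=O)[C@H](OC(C)=O)[C@H]2OC(C)=O)OC=C(C(=O)OC)[C@H]1CC(=O)OCC` has not been measured. It differs from compound 3 by methyl in place of hydrogen on a saturated chain carbon bound to an oxygen next to a carbonyl group. Among the compounds with values here, two measured steps bear on this change. The step of an at least 2.2-fold higher number from compound 1 to compound 3 (0.35 log units; beyond the scatter) shows that shortening the chain by one step beyond ethyl moved the number past the limit, while the step that the two limits leave unreadable from compound 2 to compound 3 cannot be read in size. The opposite direction, adding a methyl to compound 3, is therefore expected to lower the number, though the position at the limit of > 15000 nM in this assay, at which 2 of the 3 values shown sit, means the size of the step from compound 3 cannot be read directly. Compound 4 sits between compound 3 and compound 1 in chain length, so its number is expected to fall between their values, giving an expected step of an at least 1.5-fold lower number from compound 3 to compound 4 (0.17 log units; that floor lies within the scatter). The estimate for compound 4 in this assay is 10000 nM, within a range from 5000 nM to 20000 nM.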

Compound 4, half-maximal inhibitory concentration: > 15000 nM
Compound 4: only a limit was reported; the forecaster's own chance of this, stated with the estimate: 35%; middle value at least 1.5-fold (0.17 log units) away from the limit.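

The change from methoxycarbonyl to ethoxycarbonyl does not bring compound 4 to a readable number in this assay, and compound 4 is reported, like compound 3, only as a limit. The one step that can be read is an at least 2.2-fold higher number from compound 1 to compound 4 (0.35 log units; beyond the scatter), so among the compounds shown, compound 1 alone has an actual value, and it differs from compound 4 by methyl on a saturated chain carbon, two bonds along the chain from an oxygen next to a carbonyl group. The steps from compound 3 to compound 4 and from compound 2 to compound 4 cannot be read, and the limit now holds most of the series: the limit of > 15000 nM in this assay, at which 3 of the 4 values shown sit.

Going by these compounds, whether compound 2, compound 3 and compound 4 differ among themselves stays open, and compound 2 shows that a larger group at the chain end does not by itself give a readable number. Also open, on these data alone, is what a longer straight chain, such as butyl, or an amine or a carboxylic acid at the end of the chain would do in this assay.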